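A few compounds are considered here, and "the series" means these few. Any claim that something is new, unique, unknown or untested is made for them only; others in the source may bear on it.

Working notes on the series.

Compound 1 `CNc1cccc(NC(=O)CN2N=C(c3ccccc3)c3ccccc3N(CC(=O)C(C)(C)C)C2=O)c1` gives 132 nM in a functional assay on stomach for binding affinity to Gastrin/cholecystokinin type B receptor (Rattus norvegicus); a higher number here means weaker binding, a lower number tighter binding. Compound 2 `CNc1cccc(NC(=O)CN2N=C(c3ccccn3)c3ccccc3N(CC(=O)C(C)(C)C)C2=O)c1` gives 224 nM in this assay, and compound 3 `CCOCCNc1cccc(NC(=O)CN2N=C(C3CCCCC3)c3ccccc3N(CC(=O)C(C)(C)C)C2=O)c1` gives 105 nM. On these three numbers compound 2 has the highest value; the step of a 1.7-fold higher number from compound 1 to compound 2 (0.23 log units; within the scatter) lies within the scatter, so compound 1 and compound 2 are not separated, while compound 3 sits lower than compound 2 by more than the scatter.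

Compound 4 `CNc1cccc(NC(=O)CN2N=C(c3ccccn3)c3ccccc3N(CC(=O)N3CCCC3)C2=O)c1` is not yet measured. It differs from compound 2 in one place: pyrrolidin-1-yl in place of tert-butyl on a carbonyl carbon. Among the measured compounds shown here, none of the measured steps touches this position; the only measured step, from compound 1 to compound 2, concerns the group on the carbon with the double bond to nitrogen, and the difference between compound 2 and compound 3 combines several changes at once. For the measured compounds named here, there is therefore no measured step that bears on the change from tert-butyl to pyrrolidin-1-yl on the carbonyl carbon.

In the absence of a comparable step, compound 4 is expected to stay close to compound 2, with the step of a 1.1-fold higher number from compound 2 to compound 4 (0.05 log units; within the scatter) expected to fall within the scatter in either direction. The estimate for compound 4 in this assay is 250 nM, with a range from 80 nM to 800 nM.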

Compound 4, dissociation constant: 1050 nM
Compound 4: middle estimate off by 4.2-fold (0.62 log units), on the low side; measured number outside the range, above it.
By their numbers in this assay, from the lowest: compounds 3, 1 and 2 (each within the scatter of the next, the first and the last beyond it); then compound 4.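

In this assay, among the compounds shown here, the position on the carbonyl carbon is not indifferent to its group: pyrrolidin-1-yl in place of tert-butyl gives a 4.7-fold higher number from compound 2 to compound 4 (0.67 log units; beyond the scatter), a step beyond the scatter, whereas the one earlier single-place step, at the carbon with the double bond to nitrogen, stayed within it. The change is also small by the counts, as 4 heavy atoms without a ring give way to 5 heavy atoms in a five-membered non-aromatic ring with 1 hetero atom, and the hydrogen-bond donor and acceptor counts are 0 on both sides, so these counts do not separate the two groups. No available data account for the weaker binding that accompanies this change.

The compounds shown leave open whether the step follows the ring, the nitrogen on the carbonyl carbon or the departure of tert-butyl; cyclopentyl, which keeps the ring without the nitrogen, and dimethylamino, which keeps the nitrogen without the ring, would separate these readings. Also open, going by these compounds, is whether the same change has a similar size with the phenyl group of compound 1 in place of pyridin-2-yl.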